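This account rests on a few compounds, and the source may have more. Where it says the series, first, only, none or still open, it means among the compounds named here.

Measured in a functional assay on the whole organism (strain Wistar) for inhibition, with Rattus norvegicus as the target, with stated times of 30 min and 3 h, at a dose of 20 mg/kg by the oral route; on this read-out higher numbers stand for more inhibition at the one dose given (going by the name of the read-out) and lower numbers for less inhibition:

Compound 1, `O=C1OC(c2ccc(Cl)cc2)=C/C1=C\c1ccccc1Cl`: 81.5%
Compound 2, `O=C1OC(c2ccc(Cl)cc2)=C/C1=C\c1ccccc1[N+](=O)[O-]`: 18.5%
Compound 3, `O=C1/C(=C/c2ccc(Cl)cc2)C=C(c2ccc(Cl)cc2)N1Cc1ccccc1`: 88.9%

Compound 1 and compound 2 differ in one place, (nitro in place of chloro on an aromatic carbon), and this change gave a number 63 percentage points lower from compound 1 to compound 2 (beyond the scatter). Compound 3 has a different core from compound 1; how the two cores differ is not broken down here, and its value in this assay lies within the scatter of compound 1, so no order between them is claimed.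

Compound 4, `O=C1/C(=C/c2ccc([N+](=O)[O-])cc2)C=C(c2ccc(Cl)cc2)N1Cc1ccccc1`, has not been measured. It differs from compound 3 by nitro in place of chloro on an aromatic carbon. This is the same kind of change as that from compound 1 to compound 2, though not the same: there the nitro sits ortho to a large group, here para to a large group. Resting on the single step from compound 1 to compound 2, a large fall is expected, a number 56.9 percentage points lower from compound 3 to compound 4 (beyond the scatter), with the different core and placement leaving the size uncertain. Compound 4 is estimated at 32% in this assay, likely between 8% and 65%.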

Compound 4, a percentage reported as inhibition, in the whole organism at one dose (the size of the read-out at that dose, not a potency): 19.8%
For compound 4 the middle estimate is 12.2 percentage points above the measured one, and the stated range covers the measured number.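

Nitro in place of chloro again gave a number 69.1 percentage points lower from compound 3 to compound 4 (beyond the scatter) in this assay. Set beside the earlier step, the fall is of much the same size on both cores: the same change on two cores in this assay, a number 63 percentage points lower (beyond the scatter) from compound 1 to compound 2 and a number 69.1 percentage points lower (beyond the scatter) from compound 3 to compound 4, 6.1 percentage points apart, within the scatter of two such steps. This shows that, in these two pairs, the change carried over from one core to the other with its size kept, but two pairs make no rule for other cores and do not explain why the number falls.

Still open, from the compounds shown here alone, is what other groups in this place on the ring would give, such as an amine, a carboxylic acid or a methoxy group. Also open, going by these compounds, is whether the same fall would appear at other doses.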